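Fluoro to bromo at the cytotoxicity limit

The source may report more compounds than this note shows. Statements on the series, on what has been measured and on what is new or still open speak of the compounds shown alone.

In an ADME assay on NPC-TW01 cells (Homo sapiens) for cytotoxicity, read by MTT assay (on this read-out lower numbers stand for stronger inhibition and higher numbers for weaker inhibition), compound 1 (`C/C(COc1cccc2ccccc12)=N\O`) gives > 50000 nM as a limit of the assay, not a number. Compound 2 (`O/N=C(\COc1cccc2ccccc12)c1ccc(F)cc1`) likewise gives > 50000 nM as a limit. Among the compounds with values here, the record thus holds the limit of > 50000 nM in this assay, at which 2 of the 2 values shown sit, and no measured step. Compound 3 (`O/N=C(\COc1cccc2ccccc12)c1ccc(Br)cc1`) carries bromo in place of the fluoro of compound 2, on an aromatic carbon para to a large group, a change counted as bromo in place of fluoro on an aromatic carbon in full. In this assay the expected a number no higher from compound 2 to compound 3 (the limit leaves the size open) stays within the scatter, with no direction foreseen. For compound 3 the estimated value is 50000 nM ( expected range 20000 nM to 100000 nM).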

Compound 3, half-maximal inhibitory concentration: > 50000 nM
Compound 3 ended at the assay's limit (the forecaster's own chance of this, stated with the estimate: 70%); the middle value sits exactly at the limit.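

No step can be read from compound 2 to compound 3: both values are limits of this assay, not numbers. The compounds shown leave open whether fluoro and bromo differ at all here, and at what concentration any of the three would reach half-maximal inhibition.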